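This account rests on a few compounds, and the source may have more. Where it says the series, first, only, none or still open, it means among the compounds named here.

Measured so far:
- compound 1, `CC(C)N1CCN(Cc2csc(N)c2C(=O)c2ccc(Cl)cc2)CC1`: -1%
- compound 2, `Nc1scc(CN2CCN(c3ccc(F)cc3Cl)CC2)c1C(=O)c1ccc(Cl)cc1`: 6.1%

Both were tested in a functional assay on CHO cells with adenosine receptor A1 (Homo sapiens) as the target, read by cAMP accumulation and immunoassay, with a stated time of 6 min, tested at 0.01 uM; a higher number here means a weaker effect of the compound at the concentration tested, a lower number a stronger effect. Compound 1 gives -1% and compound 2 gives 6.1%, so on the numbers shown compound 2 sits at the same level as compound 1: the step of a number 7.1 percentage points higher from compound 1 to compound 2 (within the scatter) is within the scatter, and the two cannot be told apart. Neither shows a clear effect at the concentration tested.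

Compound 3, `Nc1scc(CN2CCN(c3ccc([N+](=O)[O-])cc3)CC2)c1C(=O)c1ccc(Cl)cc1`, has not yet been measured. It differs from compound 2 in one place: 4-nitrophenyl in place of 2-chloro-4-fluorophenyl on an amine nitrogen in a ring. For the measured compounds named here, the only measured step that bears on this change is the one on the same ring nitrogen, from compound 1 to compound 2, which swapped the group there and produced a number 7.1 percentage points higher from compound 1 to compound 2 (within the scatter), a change within the scatter. With no other information, the expected step in this assay from compound 2 to compound 3 is none beyond the scatter, a number 2.1 percentage points lower from compound 2 to compound 3 (within the scatter). The estimate for compound 3 in this assay is therefore 4%, with a range from -10% to 18%.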

Compound 3, a percentage reported as activity, at one concentration (the size of the read-out at that concentration, not a potency): -12%
Beside the measured number, compound 3's estimate is 16 percentage points above it; measured number below the stated range.
By their numbers in this assay, from the lowest: compound 3; then compounds 1 and 2 (each within the scatter of the next).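

In this assay, for the compounds shown here, the group on this ring nitrogen had so far made no difference beyond the scatter, but the change to 4-nitrophenyl gives a number 18.1 percentage points lower from compound 2 to compound 3 (beyond the scatter) and, against the isopropyl group, a number 11 percentage points lower from compound 1 to compound 3 (beyond the scatter). Both steps are modest, yet a lower number here means a stronger effect at the single concentration tested, so this position does respond to what is placed on it. The aromatic ring alone does not account for the result, since compound 2 also carries a phenyl ring at this position and sits within the scatter of compound 1, and no measurement shown here explains the step.

The change removes the chlorine and fluorine and adds the nitro group in one move, so these compounds cannot show whether losing the halogens, gaining the nitro group or both matter. As far as these compounds go, it also remains open where a plain phenyl ring, or a phenyl ring bearing a nitrile or an amine, would fall on this nitrogen, and whether the step would hold as a difference in potency.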